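The source may report more compounds than this note shows. Statements on the series, on what has been measured and on what is new or still open speak of the compounds shown alone.

Measured in a functional assay on DLD-1 cells (Homo sapiens) for cytotoxicity, with a stated time of 48 h (a lower number here means a stronger inhibitor, a higher number a weaker inhibitor), so far:
- compound 1 `CC(C)CC(=O)Oc1ccc2oc(/C=C/[S+](C)[O-])cc(=O)c2c1` gives 6100 nM
- compound 2 `Cc1ccc2oc(/C=C/[S+](C)[O-])cc(=O)c2c1` gives 7000 nM

Among the compounds with values here, compound 2 sits within the scatter of compound 1, the only other measured compound, so the series has no measured spread yet. Within the data shown here, compound 3 `C[S+]([O-])/C=C/c1cc(=O)c2cc(Cl)ccc2o1` is next, with chloro in place of methyl on an aromatic carbon of the shared core chloro in place of methyl on an aromatic carbon as its one change from compound 2. Among the measured compounds shown here, the only measured step that bears on this is a 1.1-fold higher number from compound 1 to compound 2 (0.06 log units; within the scatter) (also a replacement on an aromatic carbon) and it stays within the scatter. For the measured compounds named here, no chloro compound has been measured, so this is indirect evidence. No step beyond the scatter is expected in this assay for this replacement. The expected step is a 1.2-fold lower number from compound 2 to compound 3 (0.07 log units; within the scatter) and the direction is left open. Compound 3 is estimated at 6000 nM (range 2500 nM to 14000 nM) in this read-out.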

Compound 3, half-maximal inhibitory concentration: 6500 nM
For compound 3 the middle estimate is 1.1-fold (0.03 log units) below the measured one, within the range that was stated.
By their numbers in this assay, from the lowest: compounds 1, 3 and 2 (each within the scatter of the next).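

In this assay the same aromatic carbon of the shared core has now carried three different groups, and both new steps, a 1.1-fold lower number from compound 2 to compound 3 (0.03 log units; within the scatter) and a 1.1-fold higher number from compound 1 to compound 3 (0.03 log units; within the scatter), stay within the scatter. Chloro, methyl and (isobutylcarbonyl)oxy therefore cannot be told apart at this position in this read-out, which extends the single earlier comparison to a first halogen. No measurement is available that would explain this lack of separation.

Going by these compounds, it remains open whether any replacement at this position gives a step beyond the scatter, for example an amine, a carboxylic acid or a plain hydrogen. The side chain carrying the sulfur is the same in all three compounds, so its contribution to the cytotoxicity cannot be read from them.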